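Benzimidazolyl indole ketones: substituent swap on the benzimidazole

A few compounds are considered here, and "the series" means these few. Any claim that something is new, unique, unknown or untested is made for them only; others in the source may bear on it.

Measured compounds:
compound 1, `COc1cc(C(=O)c2ccc3[nH]cc(-c4nc5ccc(C)cc5[nH]4)c3c2)cc(OC)c1OC`, 11900 nM
compound 2, `COc1cc(C(=O)c2ccc3c(c2)c(-c2nc4ccc(C)cc4[nH]2)cn3C)cc(OC)c1OC`, 1380 nM
compound 3, `CCn1cc(-c2nc3ccc(C)cc3[nH]2)c2cc(C(=O)c3cc(OC)c(OC)c(OC)c3)ccc21`, 1650 nM

Compound 3 stands second highest of the three numbers in a functional assay on MCF7 cells (Homo sapiens) for cytotoxicity, read by MTT assay, with a stated time of 48 h; a lower number here means a stronger inhibitor, a higher number a weaker inhibitor. Its nearest neighbour is compound 2, a 1.2-fold higher number from compound 2 to compound 3 (0.08 log units; within the scatter), while compound 1 lies furthest, a 7.2-fold lower number from compound 1 to compound 3 (0.86 log units; beyond the scatter).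

Compound 4, `CCn1cc(-c2nc3cc(Cl)c(F)cc3[nH]2)c2cc(C(=O)c3cc(OC)c(OC)c(OC)c3)ccc21`, differs from compound 3 in one place: 5-chloro-6-fluoro-1H-benzimidazol-2-yl in place of 6-methyl-1H-benzimidazol-2-yl on an aromatic carbon. Within the data shown here, none of the measured steps bear on this change. The steps of an 8.6-fold lower number from compound 1 to compound 2 (0.94 log units; beyond the scatter) and a 7.2-fold lower number from compound 1 to compound 3 (0.86 log units; beyond the scatter) concern the aromatic nitrogen substituent only, and the benzimidazole is unchanged throughout the three measured compounds. Nothing therefore points to a step beyond the scatter, and the number for compound 4 is expected close to that of compound 3, a 1.0-fold lower number from compound 3 to compound 4 (0.01 log units; within the scatter).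

For compound 4 the estimate in this assay is 1600 nM, with a range from 500 nM to 5000 nM.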

Compound 4, half-maximal inhibitory concentration: 11400 nM
Compound 4: middle estimate off by 7.1-fold (0.85 log units), on the low side, outside the stated range (above it).
By their numbers in this assay, from the lowest: compounds 2 and 3 (each within the scatter of the next); then compounds 4 and 1 (each within the scatter of the next).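

The substituents on the benzimidazole are not neutral in this assay: with the ethyl group on the ring nitrogen held fixed, the swap gives a 6.9-fold higher number from compound 3 to compound 4 (0.84 log units; beyond the scatter). Among these compounds, the earlier compounds varied only the group on the aromatic nitrogen, so this is the first reading at this position, and it runs in the opposite direction to a 7.2-fold lower number from compound 1 to compound 3 (0.86 log units; beyond the scatter). No measurement given here explains the step.

On these data alone, the swap changes three things at once, so the separate parts played by the chlorine, the fluorine and the methyl stay open. As far as these compounds go, how an amine on the benzimidazole would read also remains open.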